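The compounds below may be only part of what the source reports. "The series", "measured", "known", "first", "only" and "open" are said of these compounds alone.

Measured compounds in a functional assay on A2780 cells (Homo sapiens) for antiproliferative activity, read by MTT assay, with a stated time of 3 days; a higher number here means a weaker inhibitor, a lower number a stronger inhibitor:
Compound 1, `CCCCCCCCCCCCCCCCCCOC1(c2ccc(Br)cc2)SC=C(C)n2c1noc2=O`: compound 1 gives > 100000 nM, which is a limit of the assay and not a number.
Compound 2, `CC/C=C\COC1(c2ccc(Cl)cc2)SC=C(C)n2c1noc2=O`: compound 2 gives 55000 nM.
Compound 3, `CCCCCCCCCCCCCCCCCCOC1(c2ccc(Cl)cc2)SC=C(C)n2c1noc2=O`: compound 3 gives > 100000 nM, again a limit of the assay.

Among the measured compounds shown here, compound 2 therefore stands as the only compound of the three with a real number in this assay; the other two values are limits, and only compound 2 can serve as a reference point.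

For the measured compounds named here, the single step with two measured ends, a step that the two limits leave unreadable from compound 1 to compound 3, runs between two limits and its size cannot be read; it concerns the halogen on the aromatic ring and not the chain on the oxygen, so it offers nothing on the change considered here.

Compound 4, `COC1(c2ccc(Cl)cc2)SC=C(C)n2c1noc2=O`, differs from compound 2 by hydrogen in place of but-1-en-1-yl on a saturated chain carbon bound to an oxygen on a saturated carbon. Going by the values given here, no measured step covers a change on this chain. What the values show is that both octadecyl compounds sit at the limit of > 100000 nM in this assay, at which 2 of the 3 values shown sit, while compound 2 with the pent-2-en-1-yl chain gives a number. Among the compounds with values here, the methyl chain of compound 4 lies on the short side of compound 2, where no compound has been measured, so the direction of the step cannot be taken from the data.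

Compound 4 is expected to show a step of a 1.3-fold higher number from compound 2 to compound 4 (0.10 log units; within the scatter) that may not exceed the scatter, with an estimated value of 70000 nM, between 20000 nM and 200000 nM.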

Compound 4, half-maximal inhibitory concentration: 166000 nM
Compound 4: the middle estimate sits 2.4-fold (0.38 log units) below what was measured; low and high end bracket the measured number.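

In this assay, the chain on the oxygen now has a readable step: going from (pent-2-en-1-yl)oxy to methoxy gives a 3.0-fold higher number from compound 2 to compound 4 (0.48 log units; beyond the scatter), so a change at this place can move the number beyond the usual scatter. The direction on the short side of the chain, unknown until now, is therefore set for this pair, with the longer unsaturated chain giving the lower number and the methoxy compound still giving a number rather than a limit. The octadecyl end still yields no number for comparison: the limit of > 100000 nM in this assay, at which 2 of the 4 values shown sit.

One step cannot show whether the trend along the chain has an optimum at intermediate length, and a saturated pentyl chain would be needed to separate the effect of the double bond from that of chain length, while a hexyl or decyl chain would fill the gap towards octadecyl. Also open, from the compounds shown here alone, are a terminal amine or carboxylic acid on the chain and whether the step holds with bromo in place of chloro on the aromatic ring, the step between the two octadecyl limits remaining unreadable.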